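A few compounds are considered here, and "the series" means these few. Any claim that something is new, unique, unknown or untested is made for them only; others in the source may bear on it.

Compound 1 `CCOC(CCn1c(Cc2nn(C)c(=O)c3ccccc23)nnc1SCC(=O)Nc1ccc(Cl)cc1Cl)OCC` is the starting point of this account. In an assay on 32D cells for inhibition of interleukin-15 (Mus musculus), read by resazurin assay, with stated times of 30 min and 2.5 days, in the presence of a further agent that is not named here (on this read-out higher numbers stand for weaker inhibition and lower numbers for stronger inhibition), compound 1 gives > 30000 nM, which is a limit of the assay rather than a measured number. Compound 1 therefore stands at the limit of > 30000 nM in this assay, at which 1 of the 2 values shown sits, and where its true value lies is not fixed. The set also holds compound 2 `CCOC(CCn1c(Cc2nn(C)c(=O)c3ccccc23)nnc1SCCCCCCCC(=O)Nc1ccc(Cl)cc1Cl)OCC`, which differs from compound 1 in the length of the chain that leads to the amide; in this assay compound 2 gives 16400 nM. Among the measured compounds shown here, no step between compound 1 and compound 2 is worked out here, so their two values show only that compound 2 returns a number while compound 1 does not.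

Compound 3 `Cn1nc(Cc2nnc(SCC(=O)Nc3ccc(Cl)cc3Cl)n2CCCO)c2ccccc2c1=O` is not yet measured. It differs from compound 1 by hydroxymethyl in place of diethoxymethyl on a saturated chain carbon, two bonds along the chain from an aromatic nitrogen. For the measured compounds named here, no measured step bears on this change, and compound 1 itself offers only a limit, so there is no anchor for the size of the step. The step from compound 1 to compound 3 a number no higher from compound 1 to compound 3 (the limit leaves the size open) is expected to stay within the usual scatter, as nothing measured points either way. Compound 3 is therefore expected to give 30000 nM in this assay, within a range of 10000 nM to 100000 nM, with a fair chance that only a limit is again reported.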

Compound 3, half-maximal inhibitory concentration: > 30000 nM
Compound 3 gave a limit, no number; the forecaster's own chance of this, stated with the estimate: 60%; the middle value lies on the limit itself.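

In this assay compound 3 gives > 30000 nM, which is a limit and not a number. Compound 1 also stands at a limit, and the step between compound 1 and compound 3 cannot be read. The compounds shown leave open where the true values of compound 1 and compound 3 lie, and whether hydroxymethyl in place of diethoxymethyl changes the inhibition at all.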